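The source may report more compounds than this note shows. Statements on the series, on what has been measured and on what is new or still open speak of the compounds shown alone.

Working notes on the series in a functional assay on V79 cells (Cricetulus griseus) for cytotoxicity, read by colony formation; a higher number here means a weaker inhibitor, a lower number a stronger inhibitor. Going by the values given here, compound 3 `CC1(CN)CCN(c2c(F)cc3c(=O)c(C(=O)O)cn(C4CC4)c3c2F)C1` gives 8 ug/mL, the lowest of the single numbers so far. Compound 2 `CC1(CN)CCN(c2cc3c(cc2F)c(=O)c(C(=O)O)cn3C2CC2)C1` gives 23 ug/mL. Compound 1 `COc1c(N2CCC(N)C2)c(F)cc2c(=O)c(C(=O)O)cn(C3CC3)c12` gives 45 ug/mL; 44 ug/mL; 45 ug/mL (3 entries), and its repeats agree closely, as the several entries of compound 1 in this assay, 45 ug/mL; 44 ug/mL; 45 ug/mL (3 entries) shows.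

Compound 4 `COc1c(N2CCC(C)(CN)C2)c(F)cc2c(=O)c(C(=O)O)cn(C3CC3)c12` has methoxy in place of fluoro on an aromatic carbon. Among the compounds with values here, one measured step bears on this carbon: a 2.9-fold lower number from compound 2 to compound 3 (0.46 log units; beyond the scatter), for fluoro in place of hydrogen. It is modest and lies beyond the scatter. Removing the fluoro is therefore expected to give back a number of about that size, although methoxy is not hydrogen and this remains an inference. Compound 1 also carries methoxy and reads high at 45 ug/mL; 44 ug/mL; 45 ug/mL (3 entries), but its amine-bearing ring differs, so it offers only loose support. A move to a higher number is expected, with an estimated 2.5-fold higher number from compound 3 to compound 4 (0.40 log units; beyond the scatter). For compound 4 the expected value is 20 ug/mL, with an estimated range of 9 ug/mL to 45 ug/mL.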

Compound 4, half-maximal inhibitory concentration: 38 ug/mL
Beside the measured number, compound 4's estimate is 1.9-fold (0.28 log units) below it; the range from low to high includes it.
By their numbers in this assay, from the lowest: compound 3; then compounds 2 and 4 (each within the scatter of the next).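

In this assay, this aromatic carbon, ortho to a 3-(aminomethyl)-3-methylpyrrolidin-1-yl group, now has three measured substituents, and fluoro is the one that stands apart: methoxy in place of fluoro gives a 4.8-fold higher number from compound 3 to compound 4 (0.68 log units; beyond the scatter). Methoxy in place of hydrogen gives a 1.7-fold higher number from compound 2 to compound 4 (0.22 log units; within the scatter), so methoxy and hydrogen are not separated here, and the lower number at this carbon belongs to fluoro alone among the three. Nothing in the available evidence accounts for this difference.

From the compounds shown here alone, whether the lower number is peculiar to fluoro stays open, since chloro, hydroxyl, an amine or a longer chain such as ethoxy at this carbon would each test it. Going by these compounds, whether the same order holds without the 3-(aminomethyl)-3-methylpyrrolidin-1-yl group also stays open.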